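A few compounds are considered here, and "the series" means these few. Any claim that something is new, unique, unknown or untested is made for them only; others in the source may bear on it.

Measured so far:
- compound 1 `COc1ccc(-c2coc3cc(OCCCSC(=S)N4CCCC4)ccc3c2=O)cc1`: 30800 nM
- compound 2 `COc1ccc(-c2coc3cc(OCCCCSC(=S)N4CCN(C(=O)OC(C)(C)C)CC4)ccc3c2=O)cc1`: 8840 nM

Of the compounds shown here, two have been measured in a functional assay on ECa-109 cells for inhibition, with ECa-109 cell line (Homo sapiens) as the target, read by MTT assay, with a stated time of 48 h; on this read-out lower numbers stand for stronger inhibition and higher numbers for weaker inhibition. Compound 1 gives the highest number of the two, 30800 nM; its nearest neighbour, compound 2, gives 8840 nM, a gap that lies beyond the usual scatter, so compound 1 is the weaker of the pair. Going by the values given here, no single-point step between the two has been worked out, since they differ in more than one place.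

Compound 3 `COc1ccc(-c2coc3cc(OCCCCCBr)ccc3c2=O)cc1` is not yet measured. Relative to compound 1 it carries the change (a group of 3 heavy atoms (2 carbon, 1 bromine; no ring) in place of a group of 8 heavy atoms (5 carbon, 1 nitrogen, 2 sulfur; one five-membered non-aromatic ring with 1 hetero atom), on a saturated chain carbon, three bonds along the chain from an oxygen on an aromatic ring). Among the compounds with values here, both measured compounds hold the group that leaves here, so nothing measured so far shows what its removal does. The step from compound 1 to compound 3 in this assay is expected to be small, with a lean toward a higher number, a 1.3-fold higher number from compound 1 to compound 3 (0.11 log units; within the scatter). For compound 3 the estimate is 40000 nM, with a range from 10000 nM to 150000 nM.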

Compound 3, half-maximal inhibitory concentration: 59100 nM
The estimate for compound 3 lay 1.5-fold (0.17 log units) below the measured number; low and high end bracket the measured number.
By their numbers in this assay, from the lowest: compound 2; then compounds 1 and 3 (each within the scatter of the next).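

In this assay, replacing the group of 8 heavy atoms, with its two sulfur atoms and five-membered non-aromatic ring, by 2-bromoethyl on the saturated chain carbon, three bonds along the chain from an oxygen on an aromatic ring, gives a 1.9-fold higher number from compound 1 to compound 3 (0.28 log units; within the scatter). This is the first direct reading at this position, and it shows that the larger group and the much smaller 2-bromoethyl cannot be told apart here, so the larger group is not shown to matter for this read-out. No independent measurement bears on why this exchange reads as it does.

From the compounds shown here alone, it remains open whether a different end group at this place, such as an amine or a carboxylic acid, would shift the number beyond the scatter. Going by these compounds, the effect of a longer chain carrying the same end group also remains open.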